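Furanylmethyl to isobutyl on the piperidine: expected cytotoxicity

A few compounds are considered here, and "the series" means these few. Any claim that something is new, unique, unknown or untested is made for them only; others in the source may bear on it.

Compound 1, `Cc1ccc2c(NCc3ccc(NC(=O)C4CCN(Cc5ccccc5)CC4)cc3)nc(N3CCC(N4CCCC4)CC3)nc2c1`: in a functional assay on SV5A8 cells (Homo sapiens) for cytotoxicity (a higher number here means a weaker inhibitor, a lower number a stronger inhibitor), compound 1 gives > 8090 nM, a limit of the assay.
Compound 2, `Cc1ccc2c(NCc3ccc(NC(=O)C4CCN(Cc5ccccc5)CC4)cc3)nc(N(C)CCCN(C)C)nc2c1`: compound 2 gives > 8620 nM, a limit of the assay.
Compound 3, `Cc1ccc2c(NCc3ccc(NC(=O)C4CCN(Cc5ccco5)CC4)cc3)nc(N(C)C)nc2c1`: compound 3 gives > 20000 nM, a limit of the assay.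

Compound 3 stands at the limit of this assay and not at a number. The same holds for the other two compounds, each sitting at a limit of its own the limit of > 20000 nM in this assay, at which 1 of the 3 values shown sits, the limit of > 8090 nM in this assay, at which 1 of the 3 values shown sits (the limit of > 8620 nM in this assay, at which 1 of the 3 values shown sits). Compound 4, `Cc1ccc2c(NCc3ccc(NC(=O)C4CCN(CC(C)C)CC4)cc3)nc(N(C)C)nc2c1`, differs from compound 3 in one place: isopropyl in place of furan-2-yl on a saturated chain carbon bound to an amine nitrogen in a ring. Cut one bond further out, the same change reads (furan-2-yl)methyl to isobutyl.

For the measured compounds named here, the only step between measured compounds, a step that the two limits leave unreadable from compound 1 to compound 2, concerns a different part of the shared core, and both of its ends are limits, so its size cannot be read. Going by the values given here, no measured step bears on the change from compound 3 to compound 4, and the starting point itself is a limit. Compound 4 is therefore expected to remain at or near that limit, an estimated 20000 nM with a range from 10000 nM to 40000 nM. The step this estimate means for compound 4 is expected to be a number no higher from compound 3 to compound 4 (the limit leaves the size open), not distinguishable from the scatter.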

Compound 4, half-maximal inhibitory concentration: > 10500 nM
Compound 4 gave a limit, no number; the forecaster's own chance of this, stated with the estimate: 85%; the middle value does not contradict the limit.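

Compound 3 and compound 4 both give only a limit in this assay, not a number, so the size of this step cannot be read. The compounds shown leave open whether swapping (furan-2-yl)methyl for isobutyl changes cytotoxicity at all, and at what concentration any of them would show it.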